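Dimethylamino in place of methoxy, measured once, tried again

This account rests on a few compounds, and the source may have more. Where it says the series, first, only, none or still open, it means among the compounds named here.

Three compounds have been measured in a functional assay on DU-145 cells (Homo sapiens) for inhibition, read by trypan blue exclusion, with a stated time of 96 h; on this read-out lower numbers stand for stronger inhibition of growth and higher numbers for weaker inhibition of growth:

Compound 1, `CN(C)c1ccc(/C=C(\C(=O)c2ccc(Cl)cc2)S(=O)(=O)c2ccc(Br)cc2)cc1`: > 100000 nM
Compound 2, `COc1ccc(/C=C(\C(=O)c2ccc(Cl)cc2)S(=O)(=O)c2ccc(Br)cc2)cc1`: 10000 nM
Compound 3, `COc1ccc(/C=C(\C(=O)c2ccc(Br)cc2)S(=O)(=O)c2ccc(C)cc2)cc1`: 1000 nM

The value of compound 1 is a limit of this assay and not a number, (the limit of > 100000 nM in this assay, at which 1 of the 3 values shown sits). Compound 2 gives 10000 nM in this assay, and the step of an at least 10-fold higher number from compound 2 to compound 1 (1.00 log units; beyond the scatter) comes with one change, (dimethylamino in place of methoxy on an aromatic carbon). Compound 3 gives 1000 nM, the lowest of the two numbers; the difference between the core of compound 2 and the core of compound 3 is not broken down here.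

Compound 4, `Cc1ccc(S(=O)(=O)/C(=C/c2ccc(N(C)C)cc2)C(=O)c2ccc(Br)cc2)cc1`, has not yet been measured in this assay. It differs from compound 3 by dimethylamino in place of methoxy on an aromatic carbon, the same change as before, at a place described in the same words. The expected step is a 15-fold higher number from compound 3 to compound 4 (1.18 log units; beyond the scatter), resting on the measured step of an at least 10-fold higher number from compound 2 to compound 1 (1.00 log units; beyond the scatter). Compound 4 is therefore expected to give about 15000 nM in this assay, most likely between 3000 nM and 100000 nM.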

Compound 4, concentration for 50% growth inhibition: 50000 nM
Estimate against measurement, compound 4: 3.3-fold (0.52 log units) below; low and high end bracket the measured number.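

In this assay, dimethylamino in place of methoxy on the core of compound 3 gives a 50-fold higher number from compound 3 to compound 4 (1.70 log units; beyond the scatter), so on this second core the change again goes toward weaker inhibition of growth. Set beside the earlier step, the change points the same way on both cores, though how their sizes compare stays unsettled: the same change on two cores in this assay, an at least 10-fold higher number (1.00 log units; beyond the scatter) from compound 2 to compound 1 and a 50-fold higher number (1.70 log units; beyond the scatter) from compound 3 to compound 4; the limit leaves it open whether they differ. The value of compound 1, > 100000 nM, is a limit of this assay and not a number, so the two pairs show that the direction carried over from one core to the other, but not that the size did.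

The compounds shown carry only methoxy or dimethylamino at this place on the aromatic ring, which leaves open how a hydroxyl, a primary amine or a morpholine would read there. Also open, as far as these compounds go, is whether the same step would appear on a core bearing a nitrile or a carboxylic acid in place of the halogens and methyl seen here.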